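This account rests on a few compounds, and the source may have more. Where it says the series, first, only, none or still open, it means among the compounds named here.

Three compounds have been measured in an ADME assay on the whole organism for pharmacokinetics, with Homo sapiens as the target; a lower number here means that a smaller share of the oral dose reaches the circulation, a higher number that a larger share of the oral dose reaches the circulation:

compound 1 `COc1ccccc1NS(=O)(=O)c1ccc2nc(-c3ccccc3)c(-c3ccccc3)nc2c1`: 100%
compound 2 `CC(=O)c1cccc(NS(=O)(=O)c2ccc3nc(-c4ccccc4)c(-c4ccccc4)nc3c2)c1`: 96.9%
compound 3 `O=S(=O)(Nc1ccc2ccccc2c1)c1ccc2nc(-c3ccccc3)c(-c3ccccc3)nc2c1`: 100%

In this assay compound 3 stands level with compound 1 at the digits shown, the two together the highest of the three numbers, with compound 2 nearest below. The steps recorded so far all exchange the group on the sulfonamide nitrogen: a number 3.1 percentage points lower from compound 1 to compound 2 (within the scatter), no change at the digits printed from compound 1 to compound 3 (within the scatter) and a number 3.1 percentage points higher from compound 2 to compound 3 (within the scatter), each within the scatter. Compound 4 `O=S(=O)(Nc1ccc(O)cc1)c1ccc2nc(-c3ccccc3)c(-c3ccccc3)nc2c1` makes the same kind of exchange: 4-hydroxyphenyl in place of naphthalen-2-yl on a sulfonamide nitrogen. For the measured compounds named here, none of the measured steps brings in a hydroxyl, so they guide only loosely; since every such exchange so far stayed within the scatter, a step of a number 10 percentage points lower from compound 3 to compound 4 (within the scatter) is expected, that is none beyond the scatter. Compound 4 is therefore estimated at 90%, in the range 60% to 100%.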

Compound 4, oral bioavailability: 93.9%
Estimate against measurement, compound 4: 3.9 percentage points below; the measured number falls inside the stated range.
By their numbers in this assay, from the lowest: compounds 4, 2, 1 and 3 (each within the scatter of the next).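

In this assay the 4-hydroxyphenyl group on the sulfonamide nitrogen stays within the scatter of naphthalen-2-yl (a number 6.1 percentage points lower from compound 3 to compound 4 (within the scatter)), 3-acetylphenyl (a number 3 percentage points lower from compound 2 to compound 4 (within the scatter)) and 2-methoxyphenyl (a number 6.1 percentage points lower from compound 1 to compound 4 (within the scatter)). This position therefore takes a group with one aromatic ring, a hydroxyl and a hydrogen-bond donor with no step beyond the scatter, as it does naphthalen-2-yl with two rings and no donor. The data at hand offer no explanation for this result. From the compounds shown here alone, whether an amine or a carboxylic acid in place of the hydroxyl would also stay within the scatter remains open, as does any exchange on the shared core.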